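A few compounds are considered here, and "the series" means these few. Any claim that something is new, unique, unknown or untested is made for them only; others in the source may bear on it.

Compound 1 `O=C(Nc1ccc(NCC2CCCC2)cc1Cl)c1cc(Cl)ccc1O` gives 21500 nM in an ADME assay on A549 cells (Homo sapiens) for cytotoxicity, read by resazurin assay, with a stated time of 48 h; a higher number here means that more compound is tolerated, a lower number that less compound is tolerated.
Compound 2 `CCN(CC)c1ccc(NC(=O)c2cc(Cl)ccc2O)c(Cl)c1` gives 55500 nM.
Compound 3 `COc1ccc(CNc2ccc(NC(=O)c3cc(Cl)ccc3O)c(Cl)c2)cc1` gives 80700 nM.

Compound 3 holds the highest of the three numbers, though compound 2 sits within the scatter of it; only the gap to compound 1, a 3.8-fold higher number from compound 1 to compound 3 (0.57 log units; beyond the scatter), is beyond it. Compound 4 `O=C(Nc1ccc(NCCCO)cc1Cl)c1cc(Cl)ccc1O` arises from compound 3 by 2-hydroxyethyl in place of 4-methoxyphenyl on a saturated chain carbon bound to a nitrogen on an aromatic ring. For the measured compounds named here, no measured step matches this change. Going by the values given here, the one step at the same place, a 3.8-fold higher number from compound 1 to compound 3 (0.57 log units; beyond the scatter), and the step of a 2.6-fold higher number from compound 1 to compound 2 (0.41 log units; beyond the scatter), both modest, show the amine substituent shifting the number only modestly. Compound 4 is therefore expected to move by a 1.8-fold lower number from compound 3 to compound 4 (0.25 log units; within the scatter), a modest drop or nothing beyond the scatter, giving an estimate of 45000 nM with a range from 15000 nM to 130000 nM.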

Compound 4, half-maximal cytotoxic concentration: 106000 nM
Estimate against measurement, compound 4: 2.4-fold (0.37 log units) below; the measured number falls inside the stated range.
By their numbers in this assay, from the lowest: compound 1; then compounds 2, 3 and 4 (each within the scatter of the next).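

In this assay, swapping the ring-bearing 4-methoxyphenyl group for the ringless 2-hydroxyethyl leaves the number within the scatter (a 1.3-fold higher number from compound 3 to compound 4 (0.12 log units; within the scatter)), and the same holds against the diethylamino compound (a 1.9-fold higher number from compound 2 to compound 4 (0.28 log units; within the scatter)). So at this position the aromatic ring is not required to keep the number at this level, and only the cyclopentyl compound stands apart (a 4.9-fold higher number from compound 1 to compound 4 (0.69 log units; beyond the scatter)). Nothing available explains why that compound alone differs. Still open, going by these compounds, is whether an amine or a carboxylic acid in place of the hydroxy group, or a longer chain, would keep the number at this level.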